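This account rests on a few compounds, and the source may have more. Where it says the series, first, only, none or still open, it means among the compounds named here.

In a functional assay on Ramos cells (Homo sapiens) for antiproliferative activity, read by MTT assay, with a stated time of 48 h (a higher number here means a weaker inhibitor, a lower number a stronger inhibitor), compound 1 `C=CC(=O)Nc1ccc(-c2nc(Cl)cc(Nc3ccc(C(=O)Nc4cccc(C)c4)cc3)n2)cc1` gives 5390 nM, and it stands at the lower end of the two numbers measured, though its gap to compound 2 `C=CC(=O)Nc1ccc(-c2nc(Cl)cc(Nc3ccc(C(=O)Nc4cc(C(F)(F)F)cc(C(F)(F)F)c4)cc3)n2)cc1`, which gives 6180 nM, lies within the scatter. Compound 3 `C=CC(=O)Nc1ccc(-c2nc(Cl)cc(Nc3ccc(C(=O)Nc4cc(C)ccc4C)cc3)n2)cc1` differs from compound 1 by methyl in place of hydrogen on an aromatic carbon. Within the data shown here, no measured pair shows this change, so only a step within the scatter is expected in this assay, with no clear direction. The expected step of a 1.1-fold lower number from compound 1 to compound 3 (0.03 log units; within the scatter) reflects this. Compound 3 is estimated to give 5000 nM, within a range from 2000 nM to 12500 nM.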

Compound 3, half-maximal inhibitory concentration: 16800 nM
For compound 3 the middle estimate is 3.4-fold (0.53 log units) below the measured one; the measured number lies above the stated range.
By their numbers in this assay, from the lowest: compounds 1 and 2 (each within the scatter of the next); then compound 3.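

In this assay, a methyl on the aromatic carbon ortho to a large group and para to a methyl group, turning 3-methylphenyl into 2,5-dimethylphenyl, gives a 3.1-fold higher number from compound 1 to compound 3 (0.49 log units; beyond the scatter) and so costs activity, modestly but beyond the scatter. Among these compounds, this is the first step that changes one place only, and it shows that this carbon is not indifferent to substitution. No measurement presented here accounts for the loss. From the compounds shown here alone, whether any group on this carbon brings the same loss stays open, since neither a fluorine nor a methoxy group appears there. Going by these compounds, it is also open whether the methyl would cost the same without the 3-methyl group.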